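Swapping the aryl amine substituent in a chalcone-like series

This account rests on a few compounds, and the source may have more. Where it says the series, first, only, none or still open, it means among the compounds named here.

Of the compounds shown here, three that share one core have been tested in a functional assay on PC-3 cells (Homo sapiens) for cytotoxicity, read by MTT assay; a lower number here means a stronger inhibitor, a higher number a weaker inhibitor. Compound 1 is `COc1cc(/C=C/C(=O)c2sc(Nc3ccccc3C)nc2C)cc(OC)c1OC`. In this assay compound 1 gives > 25000 nM, which is a limit of the assay rather than a measured number. Compound 2 is `COc1ccc(/C=C/C(=O)c2sc(Nc3ccc(Cl)c(Cl)c3)nc2C)cc1`; in this assay compound 2 gives > 25000 nM, again only a limit. Compound 3 is `Cc1nc(Nc2ccccc2)sc1C(=O)/C=C/c1ccccc1Cl`; in this assay compound 3 gives > 25000 nM, also a limit. So compound 1 stands nowhere above or below its two neighbours: all three sit at the same limit, as the one piece of evidence, (the limit of > 25000 nM in this assay, at which 3 of the 3 values shown sit), shows, and no step between measured compounds can be computed.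

The unmeasured compound 4 is `COc1cc(/C=C/C(=O)c2sc(Nc3cccc(Cl)c3)nc2C)cc(OC)c1OC`. Its difference from compound 1 is 3-chlorophenyl in place of 2-methylphenyl on a nitrogen on an aromatic ring. Within the data shown here, with every measured compound at the same limit, there is no measured step to lean on, and no direction for the change from compound 1 to compound 4 can be read from the numbers. The expectation in this assay is therefore no step beyond the scatter, and most likely another limit. Compound 4 is estimated to give 30000 nM, within a range of 8000 nM to 120000 nM, which means an expected step that the limit leaves unreadable from compound 1 to compound 4.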

Compound 4, half-maximal inhibitory concentration: > 25000 nM
Compound 4: a limit, no number; the forecaster's own chance of this, stated with the estimate: 80%; the middle value does not contradict the limit.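

In this assay compound 4 gives > 25000 nM as a limit of the assay, not a number. Among these compounds, compound 1 also stands at a limit, so no step from compound 1 to compound 4 can be read: the limit of > 25000 nM in this assay, at which 4 of the 4 values shown sit. The compounds shown leave open which change to the shared core, if any, in this assay would give a measured number.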